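Methoxy in Place of Chloro on the Aromatic Ring

This account rests on a few compounds, and the source may have more. Where it says the series, first, only, none or still open, it means among the compounds named here.

Of the compounds shown here, two from one series have been tested so far. Compound 1 `CC(C)[C@@H]1CC[C@@H](C)C[C@@]12N(C)C(=O)[C@@H]1[C@H]3C(=O)N(c4ccccc4)C(=O)[C@H]3ON12` gives 21.6% in a functional assay, with a stated time of 20 min, tested at 0.5 mg/mL; on this read-out lower numbers stand for a weaker effect and higher numbers for a stronger effect at the one concentration tested. Compound 2 `CC(C)[C@@H]1CC[C@@H](C)C[C@@]12N(C)C(=O)[C@@H]1[C@H]3C(=O)N(c4ccc(Cl)cc4)C(=O)[C@H]3ON12`, which differs from it only by a chloro in place of hydrogen on an aromatic carbon, gives 18.1% in this assay. The step of a number 3.5 percentage points lower from compound 1 to compound 2 (within the scatter) falls within the scatter, so on the numbers shown compound 2 stands alongside compound 1 rather than apart from it.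

Compound 3 `COc1ccc(N2C(=O)[C@H]3[C@H](ON4[C@@H]3C(=O)N(C)[C@@]43C[C@H](C)CC[C@H]3C(C)C)C2=O)cc1` is the next member and has not yet been measured. It differs from compound 2 in one place: methoxy in place of chloro on an aromatic carbon.

Among the compounds with values here, the only step that bears on this change is the one from compound 1 to compound 2, a substitution on the same aromatic carbon that stayed within the scatter. Nothing measured speaks to a methoxy at that position. On that basis the change from compound 2 to compound 3 is expected to amount to a number 1.9 percentage points higher from compound 2 to compound 3 (within the scatter) in this assay, with no step beyond the scatter. Compound 3 is therefore estimated at 20% in this assay, within a range from 8% to 35%.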

Compound 3, a percentage reported as activity, at one concentration (the size of the read-out at that concentration, not a potency): 32.9%
Beside the measured number, compound 3's estimate is 12.9 percentage points below it, within the range that was stated.
By their numbers in this assay, from the lowest: compounds 2 and 1 (each within the scatter of the next); then compound 3.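

The aromatic carbon para to a large group is not indifferent in this assay: the change from 4-chlorophenyl to 4-methoxyphenyl gives a number 14.8 percentage points higher from compound 2 to compound 3 (beyond the scatter) and thus moves the read-out beyond the scatter, whereas chloro in place of hydrogen on that same carbon had stayed within it. Methoxy also separates from the unsubstituted phenyl, with a number 11.3 percentage points higher from compound 1 to compound 3 (beyond the scatter) as the step, so the higher number of compound 3 does not depend on compound 2 as the point of comparison and this substituent is the first at that carbon to change the result beyond the scatter. No measurement in hand accounts for either step, and the numbers alone give no reason for them.

As far as these compounds go, whether the effect belongs to methoxy in particular remains open, since a hydroxy, an ethoxy or a dimethylamino group on the same carbon could show whether the step persists, shrinks or grows. Within the data shown here, it is also open whether methoxy would give a similar step on another carbon of that ring, and the read-out shows only that compound 3 has a stronger effect at the one concentration tested.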